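Replacing the aryl sulfonamide with a thiophene sulfonamide

The source may hold more compounds than are shown below. What is called first, only, known or untested is meant among the compounds shown, and "the series" means these compounds.

Of the compounds shown here, three of a shared core have been measured in an assay on cells (Endothelial cell) for binding affinity to Endothelin-1 receptor (Sus scrofa); on this read-out higher numbers stand for weaker inhibition and lower numbers for stronger inhibition. Compound 1 `COc1cccc(Oc2c(NS(=O)(=O)c3ccc(C(C)(C)C)cc3)ncnc2OCCOc2nccs2)c1` gives 12 nM. Among the compounds with values here, compound 2 `COc1cccc(Oc2c(NS(=O)(=O)c3ccc(C(C)(C)C)cc3)ncnc2OCCOc2ncc(C)cn2)c1` gives 0.86 nM, and the step of a 14-fold lower number from compound 1 to compound 2 (1.14 log units; beyond the scatter) is the only single-point change among the measured pairs. Compound 3 `Cc1ccc(-c2c(NS(=O)(=O)c3ccc(C(C)C)cc3)ncnc2OCCOc2ncc(Br)cn2)cc1` gives 0.16 nM, the lowest of the three numbers, a gap to compound 2 and to compound 1 that lies beyond the scatter in both cases.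

Compound 4 `Cc1ccc(-c2c(NS(=O)(=O)c3cccs3)ncnc2OCCOc2ncc(Br)cn2)cc1` differs from compound 3 in one place: thiophen-2-yl in place of 4-isopropylphenyl on a sulfonyl sulfur. Within the data shown here, none of the measured steps touches the sulfonyl substituent; the one measured step concerns the group on the oxygen on the saturated carbon and so offers no direct guide. In the absence of a comparable step, the author expects a moderate loss from compound 3 to compound 4, a 3.8-fold higher number from compound 3 to compound 4 (0.57 log units; beyond the scatter), since the remaining parts of compound 3 that gave 0.16 nM are kept unchanged. Compound 4 is therefore estimated at 0.6 nM in this assay, with a range from 0.12 nM to 3 nM, the width reflecting the lack of a measured step for this change.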

Compound 4, half-maximal inhibitory concentration: 3.1 nM
The estimate for compound 4 lay 5.2-fold (0.71 log units) below the measured number; the measured number lies above the stated range.
By their numbers in this assay, from the lowest: compound 3; then compound 2; then compound 4; then compound 1.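

In this assay, within the data shown here, the group on the sulfonyl sulfur proves to be a strong determinant of the number: thiophen-2-yl in place of 4-isopropylphenyl gives a 19-fold higher number from compound 3 to compound 4 (1.29 log units; beyond the scatter) on a part of the molecule that no earlier pair had varied. This is the second step printed as large in the series, after a 14-fold lower number from compound 1 to compound 2 (1.14 log units; beyond the scatter) on the group on the oxygen, so changes at both of these places can move the number substantially. The swap replaces a six-membered carbon ring of 9 heavy atoms with a five-membered ring of 5 heavy atoms, but nothing available accounts for the size of the loss.

On these data alone, whether the loss follows from the change of ring or from the absence of the isopropyl group stays open, and a plain phenyl or a thiophen-2-yl carrying an isopropyl group would bear on that question. Also open, as far as these compounds go, is whether the step keeps its size with other groups on the oxygen on the saturated carbon, such as the 5-methylpyrimidin-2-yl of compound 2.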